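A few compounds are considered here, and "the series" means these few. Any claim that something is new, unique, unknown or untested is made for them only; others in the source may bear on it.

Compound 1 `C#CCNC1CCc2c(SCCc3ccc(Br)cc3)cccc21` stands as the weaker of the two measured compounds: in an assay on isolated protein for inhibition of Amine oxidase [flavin-containing] B (Homo sapiens) (a lower number here means a stronger inhibitor, a higher number a weaker inhibitor), compound 1 gives 85300 nM, whereas compound 2 `C#CCNC1CCc2c(OCc3cccc(C(F)(F)F)c3)cccc21` gives 6410 nM, a gap beyond the usual scatter. Compound 3 `C#CCNC1CCc2c(SCCc3cccc(C)c3)cccc21` differs from compound 1 only by 3-methylphenyl in place of 4-bromophenyl on a saturated chain carbon, two bonds along the chain from a sulfur. Going by the values given here, no measured pair covers this exchange, so the size of the step is uncertain; a modest move toward a lower number is expected, with a step of a 2.1-fold lower number from compound 1 to compound 3 (0.33 log units; beyond the scatter). For compound 3 the estimated value in this assay is 40000 nM, within a range from 8000 nM to 200000 nM.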

Compound 3, half-maximal inhibitory concentration: 0.35 nM
Compound 3: the middle estimate sits 110000-fold (5.06 log units) above what was measured; the whole stated range lies above it.
By their numbers in this assay, from the lowest: compound 3; then compound 2; then compound 1.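

In this assay the exchange of 4-bromophenyl for 3-methylphenyl gives a 240000-fold lower number from compound 1 to compound 3 (5.39 log units; beyond the scatter) and shows that this one place, on a saturated chain carbon, two bonds along the chain from a sulfur, can move the read-out enormously. The earlier compounds shown here held no single-place step, and the two groups here have the same heavy-atom count. Nothing available explains the size of this step. The compounds shown do not separate the change from bromine to methyl from the change in substituent place. A 4-methylphenyl or 3-bromophenyl group on this chain would address that question.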